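Methylating a Phenol on a Cytotoxic Scaffold: An Expectation

The source may report more compounds than this note shows. Statements on the series, on what has been measured and on what is new or still open speak of the compounds shown alone.

Within the data shown here, compound 2 `N#CC1=C(N)N(c2ccc(S(N)(=O)=O)cc2)C2=C(CCCC2)C1c1c(O)ccc2ccccc12` stands at the lower of the two numbers measured so far in a functional assay on Ehrlich cells (Mus musculus) for cytotoxicity, read by trypan blue exclusion, with a stated time of 2 h, tested at 100 ug/mL (a lower number here means a weaker effect, a higher number a stronger effect of the compound at the concentration tested), where compound 2 gives 50%. Among the measured compounds shown here, its only measured neighbour is compound 1 `N#CC1=C(N)N(c2ccc(S(N)(=O)=O)cc2)C2=C(CCCC2)C1/C=C/c1ccccc1`, which carries a 2-phenylethenyl group on a saturated ring carbon and which in this assay gives 70%. For the measured compounds named here, the change a number 20 percentage points lower from compound 1 to compound 2 (beyond the scatter) is the one comparison available, and it is a swap of one ring group for another rather than a change on the hydroxy group itself.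

Compound 3 `COc1ccc2ccccc2c1C1C(C#N)=C(N)N(c2ccc(S(N)(=O)=O)cc2)C2=C1CCCC2` differs from compound 2 in a single place: methyl in place of hydrogen on an oxygen on an aromatic ring. Going by the values given here, no measured step touches the oxygen of that ring, so the size of this particular step cannot be read from the data. With nothing pointing in either direction, the expected change from compound 2 to compound 3 is estimated as none beyond the scatter, no change at the digits printed from compound 2 to compound 3 (within the scatter). Compound 3 is therefore expected to give about 50% in this assay, within an estimated range from 30% to 70%.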

Compound 3, a percentage reported as activity, at one concentration (the size of the read-out at that concentration, not a potency): 50%
The estimate for compound 3 equals the measured number at the digits printed, within the range that was stated.
By their numbers in this assay, from the lowest: compounds 2 and 3 (each within the scatter of the next); then compound 1.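

Among these compounds, the change from hydroxy to methoxy gives the first reading at this oxygen: in this assay the step shows no change at the digits printed from compound 2 to compound 3 (within the scatter) for methyl in place of hydrogen on an oxygen on an aromatic ring. At this position and at the single concentration tested, the hydrogen on the oxygen can therefore give way to a methyl with no shift that stands clear of the scatter, something the earlier comparison of compound 1 with compound 2 could not show, since that step exchanged a whole group on a saturated ring carbon and left this oxygen out of the picture. Nothing available here bears on why the read-out holds steady at this oxygen.

As far as these compounds go, what remains open is whether the same holds for something larger on the oxygen, such as an ethyl group or a longer chain, or for an amine or a carboxylic acid in place of the hydroxy group. Also open, from the compounds shown here alone, is whether compound 2 and compound 3 would stay level at other concentrations, since a reading at one concentration is the size of an effect and not a potency.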